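The source may report more compounds than this note shows. Statements on the series, on what has been measured and on what is new or still open speak of the compounds shown alone.

Compound 1, `CCn1c(/C=C2\SC(=O)N(CC(=O)N3CCCC3)C2=O)nc2ccccc21`: > 50000 nM in a functional assay on PC-3 cells (Homo sapiens) for inhibition, read by MTT assay, with a stated time of 48 h; on this read-out lower numbers stand for stronger inhibition and higher numbers for weaker inhibition
Compound 2, `CC(C)n1c(/C=C2\SC(=O)N(CC(=O)N3CCOCC3)C2=O)nc2ccccc21`: > 50000 nM in this assay

The value for compound 1 is a limit of the assay, not a measured number. The value for compound 2 is likewise a limit. Among the compounds with values here, both values sit at the limit of > 50000 nM in this assay, at which 2 of the 2 values shown sit, so compound 2 stands at the edge of what this assay can report, and no pair of measured compounds differing in only one place is available to show how any single change shifts the read-out.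

Compound 3, `CC(C)n1c(/C=C2\SC(=O)N(CC(=O)N3CCCC3)C2=O)nc2ccccc21`, has not yet been measured in this assay. It differs from compound 2 by pyrrolidin-1-yl in place of morpholin-4-yl on a carbonyl carbon. Within the data shown here, with no measured step to lean on, the expected change is none beyond the usual scatter. Compound 3 is therefore expected to give about 60000 nM, with a range from 20000 nM to 200000 nM, most likely again as a limit. The expected step that the limit leaves unreadable from compound 2 to compound 3 is thus estimated as essentially flat.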

Compound 3, half-maximal inhibitory concentration: > 50000 nM
Compound 3: only a limit was reported; the forecaster's own chance of this, stated with the estimate: 80%; the middle value lies beyond the limit too.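

Compound 1, compound 2 and compound 3 all stop at a limit of this assay, so neither step between them, from compound 2 or from compound 1 to compound 3, can be read: the limit of > 50000 nM in this assay, at which 3 of the 3 values shown sit.

The compounds shown leave open which change to the shared core, if any, would give a measurable value in this assay.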